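The compounds below may be only part of what the source reports. "The series", "measured", "known", "first", "only" and "open" are said of these compounds alone.

In a functional assay on MCF7 cells (Homo sapiens) for inhibition, read by sulforhodamine B assay, with a stated time of 72 h (on this read-out higher numbers stand for weaker inhibition of growth and lower numbers for stronger inhibition of growth), compound 3 (`CNC(=O)CCc1ccncc1-c1ccc2ccccc2c1`) gives > 10000 nM, which is a limit and not a number. Compound 2 (`O=C(O)/C=C/c1ccncc1-c1ccc2ccccc2c1`) gives > 10000 nM, also a limit. Compound 1 (`CNC(=O)/C=C/c1ccncc1-c1ccc2ccccc2c1`) gives a number, 9340 nM. The series therefore lies close to the limit of > 10000 nM in this assay, at which 2 of the 3 values shown sit.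

Compound 4 (`COC(=O)/C=C/c1ccncc1-c1ccc2ccccc2c1`) has 2-(methoxycarbonyl)ethenyl in place of the 2-(methylcarbamoyl)ethyl of compound 3 on an aromatic carbon, opposite the ring nitrogen (2-(methoxycarbonyl)ethenyl in place of 2-(methylcarbamoyl)ethyl on an aromatic carbon). Among the compounds with values here, two measured steps bear on this change. Saturating the chain gave an at least 1.0-fold higher number from compound 1 to compound 3 (0.02 log units; that floor lies within the scatter), and replacing methylamino with hydroxy on the carbonyl carbon gave an at least 1.0-fold higher number from compound 1 to compound 2 (0.02 log units; that floor lies within the scatter). Both sizes are only floors, and neither shows a change beyond the scatter. The third step, a step that the two limits leave unreadable from compound 2 to compound 3, adds no size.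

No step beyond the scatter is therefore expected in this assay, and the estimated step is an at least 1.1-fold lower number from compound 3 to compound 4 (0.04 log units; that floor lies within the scatter). The expected value for compound 4 is 9000 nM, with an estimated range of 4000 nM to 20000 nM.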

Compound 4, concentration for 50% growth inhibition: 8170 nM
Beside the measured number, compound 4's estimate is 1.1-fold (0.04 log units) above it; low and high end bracket the measured number.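

In this assay, compound 4 supplies a second number in the series, so methoxy and methylamino can be compared directly on the carbonyl carbon, giving a 1.1-fold lower number from compound 1 to compound 4 (0.06 log units; within the scatter). Against the two limits, only floors can be read: 2-(methoxycarbonyl)ethenyl in place of 2-(methylcarbamoyl)ethyl gives an at least 1.2-fold lower number from compound 3 to compound 4 (0.08 log units; that floor lies within the scatter), and methyl in place of hydrogen on the oxygen gives an at least 1.2-fold lower number from compound 2 to compound 4 (0.08 log units; that floor lies within the scatter). No change at this position, opposite the ring nitrogen, is thus shown to move the read-out beyond the scatter, and the series stays close to a limit: the limit of > 10000 nM in this assay, at which 2 of the 4 values shown sit.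

Going by these compounds, the true sizes of the two steps read as floors remain open. So does the effect of an amine or a longer chain on this aromatic carbon.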